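Swapping the aryl group on the hydrazone of compound 3

The source may report more compounds than this note shows. Statements on the series, on what has been measured and on what is new or still open speak of the compounds shown alone.

In a functional assay on A549 cells (Homo sapiens) for antiproliferative activity, read by MTT assay (on this read-out higher numbers stand for weaker inhibition and lower numbers for stronger inhibition), compound 3 `Cc1cc(C)c(/C=N/Nc2ncc3c(n2)n(C2CCCC2)c(=O)c(=O)n3C)c(C)c1` gives 12000 nM. Among the numbers shown it is the lowest of two; its nearest neighbour, compound 2 `Cn1c(=O)c(=O)n(C2CCCC2)c2nc(N/N=C/c3ccc(S(C)(=O)=O)cc3)ncc21`, gives 84500 nM in this assay. Compound 1 `Cn1c(=O)c(=O)n(C2CCCC2)c2nc(N/N=C/c3ccc(O)cc3)ncc21` reaches only the limit of this assay, where it gives > 100000 nM; this is the limit of > 100000 nM in this assay, at which 1 of the 3 values shown sits.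

Compound 4 `Cn1c(=O)c(=O)n(C2CCCC2)c2nc(N/N=C/c3cccc([N+](=O)[O-])c3)ncc21` differs from compound 3 in one place: 3-nitrophenyl in place of 2,4,6-trimethylphenyl on a carbon with a double bond to nitrogen. The measured steps that change the same aryl group in the other direction are an at least 8.3-fold lower number from compound 1 to compound 3 (0.92 log units; beyond the scatter) and a 7.0-fold lower number from compound 2 to compound 3 (0.85 log units; beyond the scatter). Both steps put the 2,4,6-trimethylphenyl well ahead of a para-substituted phenyl, so moving from it to 3-nitrophenyl is expected to raise the number in this assay, by a step estimated as a 3.3-fold higher number from compound 3 to compound 4 (0.52 log units; beyond the scatter). Nothing measured tells how far a 3-nitrophenyl sits from a 4-hydroxyphenyl or a 4-(methylsulfonyl)phenyl, so the range is wide. Compound 4 is therefore estimated at 40000 nM in this assay, between 12000 nM and 150000 nM.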

Compound 4, half-maximal inhibitory concentration: 12300 nM
Compound 4: middle estimate off by 3.3-fold (0.51 log units), on the high side, and the stated range covers the measured number.
By their numbers in this assay, from the lowest: compounds 3 and 4 (each within the scatter of the next); then compound 2. At a limit, above all of these: compound 1.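

Among these compounds, the 3-nitrophenyl and the 2,4,6-trimethylphenyl cannot be told apart in this assay, with a 1.0-fold higher number from compound 3 to compound 4 (0.01 log units; within the scatter), so the trimethyl-substituted ring is not the only aryl group at this carbon that reaches this level. The 3-nitrophenyl also shows a 6.9-fold lower number from compound 2 to compound 4 (0.84 log units; beyond the scatter) in place of 4-(methylsulfonyl)phenyl, and an at least 8.1-fold lower number from compound 1 to compound 4 (0.91 log units; beyond the scatter) in place of 4-hydroxyphenyl. The second of these steps is only a floor, because compound 1 stands at a limit of the assay: the limit of > 100000 nM in this assay, at which 1 of the 4 values shown sits.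

What compound 3 and compound 4 have in common that sets them apart from compound 2 cannot be said from these four compounds. From the compounds shown here alone, whether an unsubstituted phenyl, a 4-nitrophenyl or a 3-aminophenyl would sit with compound 3 and compound 4 also stays open.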